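The source may hold more compounds than are shown below. What is called first, only, known or untested is meant among the compounds shown, and "the series" means these compounds.

Working notes on the series, all read in a functional assay on HeLa cells (Homo sapiens) for inhibition, read by CCK-8 assay, with a stated time of 48 h; on this read-out higher numbers stand for weaker inhibition and lower numbers for stronger inhibition. Compound 1 (`COc1cc(-c2ccnc3cc(-c4ccc5c(ccn5C)c4)nn23)cc(OC)c1OC`) gives 19 nM, compound 2 (`COc1cc(-c2ccnc3cc(-c4cn(C)c5ccccc45)nn23)cc(OC)c1OC`) gives 399 nM, and compound 3 (`C=Cc1ccc(-c2cc3nccc(-c4cc(OC)c(OC)c(OC)c4)n3n2)cc1`) gives 882 nM. That last number is the highest of the three, so compound 3 is the weakest inhibitor so far.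

Compound 4 (`COc1ccc(-c2cc3nccc(-c4cc(OC)c(OC)c(OC)c4)n3n2)cc1`) carries methoxy in place of vinyl on an aromatic carbon, para to a large group, so that 4-vinylphenyl becomes 4-methoxyphenyl: methoxy in place of vinyl on an aromatic carbon.

Among the compounds with values here, no measured step makes this exact change. The nearest evidence comes from exchanging the whole group on the shared core: a 46-fold higher number from compound 1 to compound 3 (1.67 log units; beyond the scatter) is large, a 21-fold higher number from compound 1 to compound 2 (1.32 log units; beyond the scatter) is also large, and a 2.2-fold higher number from compound 2 to compound 3 (0.34 log units; beyond the scatter) is modest. The last of these, between compound 2 and compound 3, is the best guide. Compound 4 keeps the phenyl ring, so no step beyond the scatter is expected, with a slight lean towards a lower number.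

The expected step is a 1.6-fold lower number from compound 3 to compound 4 (0.21 log units; within the scatter). For compound 4 the estimated value is 550 nM, with an expected range from 170 nM to 1800 nM.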

Compound 4, half-maximal inhibitory concentration: 373 nM
Estimate against measurement, compound 4: 1.5-fold (0.17 log units) above, and the stated range covers the measured number.
By their numbers in this assay, from the lowest: compound 1; then compounds 4 and 2 (each within the scatter of the next); then compound 3.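

In this assay, the group para to a large group on this six-membered aromatic ring does move the number, and a 2.4-fold lower number from compound 3 to compound 4 (0.37 log units; beyond the scatter) is a modest step beyond the scatter for methoxy in place of vinyl, an exchange of 2 heavy atoms for 2 heavy atoms. The 4-methoxyphenyl group cannot be told apart from the 1-methyl-1H-indol-3-yl group in a 1.1-fold lower number from compound 2 to compound 4 (0.03 log units; within the scatter) but remains far from the 1-methyl-1H-indol-5-yl group in a 20-fold higher number from compound 1 to compound 4 (1.29 log units; beyond the scatter) and so leaves compound 1 alone at the low end of the series. No supporting data bear on why these steps take these sizes.

From the compounds shown here alone, how an amine, a hydroxyl or a fluorine would read in place of methoxy remains open. So does whether any group on this phenyl ring could close the gap to compound 1.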